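The source may hold more compounds than are shown below. What is called first, only, known or untested is meant among the compounds shown, and "the series" means these compounds.

Measured in a functional assay, with a stated time of 20 min, tested at 2 uM; a lower number here means a weaker effect, a higher number a stronger effect of the compound at the concentration tested:
compound 1 `COc1cc(/C=C/C(=O)C2=C(/C=C/c3ccc(O)c(OC)c3)NC(=O)NC2c2ccc(C)cc2)ccc1O` gives 15.5%
compound 2 `COc1cc(/C=C/C(=O)C2=C(/C=C/c3ccc(O)c(OC)c3)NC(=O)NC2c2ccc(O)cc2)ccc1O` gives 33.3%

Of these two, compound 2 stands higher: the step of a number 17.8 percentage points higher from compound 1 to compound 2 (beyond the scatter) came from a hydroxy in place of methyl on an aromatic carbon. Compound 3 `COc1cc(/C=C/C(=O)C2=C(/C=C/c3ccc(O)c(OC)c3)NC(=O)NC2c2ccc(N(C)C)cc2)ccc1O` changes that same position again: dimethylamino in place of hydroxy on an aromatic carbon. Among the measured compounds shown here, no measured step covers a dimethylamino group, so the only guide is the modest size of a number 17.8 percentage points higher from compound 1 to compound 2 (beyond the scatter), which suggests a step of similar or smaller size, most likely downward, in this assay. Compound 3 is therefore estimated at 22%, between 8% and 40%. That estimate means a step of a number 11.3 percentage points lower from compound 2 to compound 3 (beyond the scatter), expected to stay modest.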

Compound 3, a percentage reported as activity, at one concentration (the size of the read-out at that concentration, not a potency): 28.2%
Compound 3: the middle estimate sits 6.2 percentage points below what was measured; the measured number falls inside the stated range.
By their numbers in this assay, from the lowest: compound 1; then compounds 3 and 2 (each within the scatter of the next).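

Hydroxy and dimethylamino cannot be told apart at this position: replacing one with the other gives a number 5.1 percentage points lower from compound 2 to compound 3 (within the scatter). Dimethylamino still keeps its distance from methyl, with a number 12.7 percentage points higher from compound 1 to compound 3 (beyond the scatter), so the edge over methyl does not depend on the hydrogen-bond donor of hydroxy, since dimethylamino has 0 hydrogen-bond donors. Nothing available explains why either group differs from methyl. Going by these compounds, whether a methoxy group, a plain amine or a carboxylic acid at this position would behave more like hydroxy or like methyl remains open.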